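The compounds below may be only part of what the source reports. "The series", "measured", "known", "first", "only" and "open" are said of these compounds alone.

Working notes on the series sharing the core of compound 1 `O=C(CN(c1nc(Cl)nc2[nH]cnc12)C1CC1)N[C@@H](CO)C(=O)OCc1ccccc1`. In a functional assay on the whole organism (Tail, strain ICR) with Mus musculus as the target, in the tail flick test, with a stated time of 30 min, at a dose of 25 umol/kg by the oral route (a higher number here means a stronger effect of the compound at the dose given, a lower number a weaker effect), compound 1 gives 31.9%. Compound 2 `C[C@H](NC(=O)CN(c1nc(Cl)nc2[nH]cnc12)C1CC1)C(=O)OCc1ccccc1` gives 41.2% in this assay, and compound 3 `O=C(O)[C@@H]1CCCN1C(=O)CN(c1nc(Cl)nc2[nH]cnc12)C1CC1` gives 31.5%. Compound 2 carries the top number of the three, but the gaps to compound 1 and to compound 3 are both within the usual scatter, so the three measured compounds cannot be ranked on these values.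

For the measured compounds named here, the one step so far within the set, a number 9.3 percentage points higher from compound 1 to compound 2 (within the scatter), is the only change measured on the side chain carried by the amide-type nitrogen, and it did not move the read-out beyond the scatter.

Compound 4 `O=C(CN(c1nc(Cl)nc2[nH]cnc12)C1CC1)NCC(=O)OCc1ccccc1` differs from compound 2 by hydrogen in place of methyl on a saturated chain carbon bound to an amide-type nitrogen and a carbonyl carbon. This change also sits on that side chain, one bond closer to the amide-type nitrogen than the change from compound 1 to compound 2. With a single bearing step, and that step within the scatter, no step beyond the scatter is expected in this assay for compound 4; the step from compound 2 to compound 4 is estimated as a number 4.2 percentage points lower from compound 2 to compound 4 (within the scatter). Compound 4 is therefore expected to give about 37% in this assay, with a range from 20% to 54%.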

Compound 4, a percentage reported as activity, at one dose (the size of the read-out at that dose, not a potency): 18.7%
The estimate for compound 4 lay 18.3 percentage points above the measured number, outside the stated range (below it).
By their numbers in this assay, from the lowest: compound 4; then compounds 3, 1 and 2 (each within the scatter of the next).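

In this assay, for the compounds shown here, the saturated chain carbon bound to an amide-type nitrogen and a carbonyl carbon is the first place where a single change moves the read-out beyond the scatter. Hydrogen in place of methyl there gives a number 22.5 percentage points lower from compound 2 to compound 4 (beyond the scatter) and hydrogen in place of hydroxymethyl gives a number 13.2 percentage points lower from compound 1 to compound 4 (beyond the scatter) so both compounds with a group on this carbon stand above compound 4, whereas the step between those two compounds, a number 9.3 percentage points higher from compound 1 to compound 2 (within the scatter) does not separate methyl from hydroxymethyl. The data at hand offer no measured grounds for explaining the lower number with hydrogen on this carbon.

From the compounds shown here alone, whether an isopropyl group, a longer chain or an aminomethyl group on this carbon would keep the read-out level with methyl and hydroxymethyl or take it beyond them remains open. Also open, going by these compounds, is whether the same steps would hold at other doses or times, since the read-out here is the size of the effect at one dose and not a potency.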